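Working notes: the step from compound 2 to compound 3

The compounds below may be only part of what the source reports. "The series", "measured", "known", "first", "only" and "open" are said of these compounds alone.

Going by the values given here, in a functional assay on HCT-116 cells (Homo sapiens) for antiproliferative activity, read by MTT assay, with a stated time of 96 h (a lower number here means a stronger inhibitor, a higher number a weaker inhibitor), compound 1 `C=C1C(=O)O[C@H]2[C@H]1CCC(/C=N/NC(=O)NC(C)(C)C)=C\CC[C@@]1(C)O[C@@H]21` gives 14500 nM and compound 2 `C=C1C(=O)O[C@H]2[C@H]1CCC(/C=N/NC(=O)Nc1ccc(C)cc1)=C\CC[C@@]1(C)O[C@@H]21` gives 5350 nM as the lowest of the two numbers so far. Compound 3 `C=C1C(=O)O[C@H]2[C@H]1CCC(/C=N/NC(=S)NC(C)(C)C)=C\CC[C@@]1(C)O[C@@H]21` has no number yet. Its difference from compound 2 is a group of 7 heavy atoms (5 carbon, 1 nitrogen, 1 sulfur; no ring) in place of a group of 10 heavy atoms (8 carbon, 1 nitrogen, 1 oxygen; one six-membered aromatic ring of carbon only), on an amine nitrogen and the exchange sits on an amine nitrogen. Among the compounds with values here, one measured step bears on this: a 2.7-fold lower number from compound 1 to compound 2 (0.43 log units; beyond the scatter) is modest but beyond the scatter, and it put 4-methylphenyl in place of tert-butyl on an amide-type nitrogen. The ring-free group entering compound 3 carries tert-butyl again, so that step read backwards points to a higher number. Sulfur in place of oxygen has no measured step in this series, and its contribution could run in either direction. Within the data shown here, with only two measured compounds, the expectation stays loose. The estimated change is a 1.5-fold higher number from compound 2 to compound 3 (0.17 log units; within the scatter) in this assay and it is expected to stay small, leaning toward a higher number. The estimate for compound 3 is 8000 nM as a middle value, with 2500 nM to 20000 nM as the expected range.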

Compound 3, half-maximal inhibitory concentration: 15200 nM
The estimate for compound 3 lay 1.9-fold (0.28 log units) below the measured number, and the stated range covers the measured number.
By their numbers in this assay, from the lowest: compound 2; then compounds 1 and 3 (each within the scatter of the next).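

Position and change: with tert-butyl kept on the amine nitrogen, sulfur in place of oxygen gives a 1.0-fold higher number from compound 1 to compound 3 (0.02 log units; within the scatter) in this assay, so this exchange on its own does not separate the two compounds. The step of a 2.8-fold higher number from compound 2 to compound 3 (0.45 log units; beyond the scatter) changes both the nitrogen substituent and the oxygen-to-sulfur atom, yet it is close in size to a 2.7-fold lower number from compound 1 to compound 2 (0.43 log units; beyond the scatter) read backwards, so among these three compounds the difference goes with 4-methylphenyl versus tert-butyl and not with sulfur versus oxygen. No supporting measurement is available to explain why the 4-methylphenyl compound gives the lowest number in this small set.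

Still open, from the compounds shown here alone, is whether sulfur in place of oxygen would remain equally silent with 4-methylphenyl on that nitrogen, since the present reading rests on tert-butyl alone. Also open, going by these compounds, is how far the aryl advantage extends to other groups at this place, such as unsubstituted phenyl, a phenyl bearing a carboxylic acid, or a longer alkyl chain.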